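The compounds below may be only part of what the source reports. "The series", "measured", "known", "first", "only" and "open" are said of these compounds alone.

Measured so far:
compound 1, `CCO/C(O)=C1\C(COCCNC(=O)c2cccnc2)=NC(C)=C(C(=O)OC)C1c1ccccc1Cl`, gives 15.9 nM
compound 2, `CCO/C(O)=C1\C(COCCNCC(=O)NC)=NC(C)=C(C(=O)OC)C1c1ccccc1Cl`, gives 25.1 nM

Both numbers come from a functional assay (aorta) with Rattus norvegicus as the target; a lower number here means a stronger inhibitor, a higher number a weaker inhibitor. Compound 1 has the lowest of the two numbers, and its nearest neighbour is compound 2; since the step is a 1.6-fold higher number from compound 1 to compound 2 (0.20 log units; within the scatter), the two cannot be told apart on this evidence. Compound 3, `CCO/C(O)=C1\C(COCCNCC(=O)NCCN)=NC(C)=C(C(=O)OC)C1c1ccccc1Cl`, is not yet measured. It differs from compound 1 in one place: ((2-aminoethyl)carbamoyl)methyl in place of (pyridin-3-yl)carbonyl on an amine nitrogen. Within the data shown here, the only measured step that bears on this change is the one in which (methylcarbamoyl)methyl replaced (pyridin-3-yl)carbonyl on the same amine nitrogen, and that step remained within the scatter; compound 3 carries ((2-aminoethyl)carbamoyl)methyl in the same place, so no step beyond the scatter is expected in this assay either. For compound 3 the expected step is a 1.6-fold higher number from compound 1 to compound 3 (0.20 log units; within the scatter). The estimate for compound 3 is therefore 25 nM, with a range from 8 nM to 80 nM.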

Compound 3, half-maximal inhibitory concentration: 100 nM
For compound 3 the middle estimate is 4.0-fold (0.60 log units) below the measured one; measured number outside the range, above it.
By their numbers in this assay, from the lowest: compounds 1 and 2 (each within the scatter of the next); then compound 3.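

In this assay, ((2-aminoethyl)carbamoyl)methyl in place of (pyridin-3-yl)carbonyl on the amine nitrogen gives a clear change (a 6.3-fold higher number from compound 1 to compound 3 (0.80 log units; beyond the scatter)), so this position is not indifferent to what it carries, even though (methylcarbamoyl)methyl there stayed within the scatter (a 1.6-fold higher number from compound 1 to compound 2 (0.20 log units; within the scatter)). The pair differing only at the chain end is more telling: aminomethyl in place of hydrogen on the saturated chain carbon bound to the amide-type nitrogen also moves the number beyond the scatter (a 4.0-fold higher number from compound 2 to compound 3 (0.60 log units; beyond the scatter)), so the higher number goes with that added aminomethyl, not with the loss of (pyridin-3-yl)carbonyl alone. Nothing available explains this shift.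

As far as these compounds go, it remains open whether the terminal amine or the extra chain length matters more. A plain ethyl or a 2-hydroxyethyl group on the amide nitrogen would separate the two.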